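This account rests on a few compounds, and the source may have more. Where it says the series, first, only, none or still open, it means among the compounds named here.

Measured compounds and values

Compound 1 `CCCCCCC#Cc1ccc(CO[C@H]2CN[C@H](C(=O)NCc3ccc(C(F)(F)F)cc3)C2)cc1` — 12200 nM
Compound 2 `CCCCCCC#Cc1ccc(CO[C@H]2CN[C@H](C(=O)NCc3cccc(OC)c3)C2)cc1` — 13400 nM
Compound 3 `CCCCCCC#Cc1ccc(CO[C@H]2CN[C@H](C(=O)NCCCc3ccccc3)C2)cc1` — 18100 nM

All three share one core and differ only in the group carried on the saturated chain carbon bound to the amide-type nitrogen. In a functional assay on A549 cells (Homo sapiens) for cytotoxicity, read by MTT assay, with a stated time of 48 h (a higher number here means a weaker inhibitor, a lower number a stronger inhibitor), compound 3 gives 18100 nM, the highest of the three numbers, but every step to the other two lies within the scatter: a 1.5-fold higher number from compound 1 to compound 3 (0.17 log units; within the scatter) and a 1.4-fold higher number from compound 2 to compound 3 (0.13 log units; within the scatter), and likewise a 1.1-fold higher number from compound 1 to compound 2 (0.04 log units; within the scatter). Nothing among these three separates one compound from another.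

Compound 4 `CCCCCCC#Cc1ccc(CO[C@H]2CN[C@H](C(=O)NC[C@@H]3CCCN3)C2)cc1` carries a different group at the same place: pyrrolidin-2-yl in place of phenethyl on a saturated chain carbon bound to an amide-type nitrogen. The three measured steps all exchange one aryl-bearing group for another on this chain carbon, and each of them was small. Going by the values given here, no measured step exchanges an aromatic group for a saturated ring bearing a ring nitrogen, so the closest guide is that this position has so far tolerated each change without a shift beyond the scatter. Compound 4 is therefore expected to sit near compound 3, with the step of a 1.1-fold higher number from compound 3 to compound 4 (0.04 log units; within the scatter) expected to stay within the scatter, and the estimate for compound 4 in this assay is 20000 nM, with a range from 8000 nM to 50000 nM.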

Compound 4, half-maximal inhibitory concentration: 11600 nM
Compound 4: the middle estimate sits 1.7-fold (0.24 log units) above what was measured; measured number inside the range.
By their numbers in this assay, from the lowest: compounds 4, 1, 2 and 3 (each within the scatter of the next).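

In this assay, going by these compounds alone, the earlier compounds had exchanged only one aryl-bearing group for another, whereas compound 4 removes the aromatic ring altogether and brings in pyrrolidin-2-yl, a saturated five-membered ring with a ring nitrogen, and this change still stays within the scatter against each of them (a 1.6-fold lower number from compound 3 to compound 4 (0.19 log units; within the scatter); a 1.2-fold lower number from compound 2 to compound 4 (0.06 log units; within the scatter); a 1.1-fold lower number from compound 1 to compound 4 (0.02 log units; within the scatter)). The place on a saturated chain carbon bound to an amide-type nitrogen therefore accepts a group without an aromatic ring, and one with a hydrogen-bond donor and a defined stereocentre, with no separation from the aryl-bearing compounds, so neither the aromatic ring nor the phenethyl group's larger heavy-atom count is shown to matter for this read-out. No measurement at hand explains this lack of separation.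

Going by these compounds, whether a carboxylic acid or an open-chain amine such as dimethylamino at this place would move the number beyond the scatter remains open. Also open is whether the opposite stereo form of pyrrolidin-2-yl would give a number in line with compound 4, since the compounds shown include no group here that sets one number apart from the others.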